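The compounds below may be only part of what the source reports. "The series", "measured", "known", "first", "only" and "open" are said of these compounds alone.

Of the compounds shown here, two have so far been measured in an assay on isolated protein for displacement of a labelled ligand from 5-hydroxytryptamine receptor 6 (Homo sapiens), read by scintillation counting, with a stated time of 1 h; on this read-out lower numbers stand for stronger inhibition and higher numbers for weaker inhibition. Compound 1 `COc1ccc2c(ccn2S(=O)(=O)c2ccccc2)c1` gives 127 nM in this assay, and compound 2 `CC(=O)N1CCN(c2cn(S(=O)(=O)c3ccccc3)c3ccccc23)CC1` gives 97 nM, the lower of the two numbers, although its gap to compound 1 lies within the scatter. Compound 3 `CN(C)c1cn(S(=O)(=O)c2ccccc2)c2ccccc12` has not yet been measured in this assay; it differs from compound 2 by dimethylamino in place of 4-acetylpiperazin-1-yl on an aromatic carbon. Among the compounds with values here, no measured step resembles this change, so only a modest shift, if any, is expected. Compound 3 is expected to give 150 nM in this assay, within 40 nM to 600 nM, a step of a 1.5-fold higher number from compound 2 to compound 3 (0.19 log units; within the scatter) that need not exceed the scatter.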

Compound 3, inhibition constant: 474 nM
Estimate against measurement, compound 3: 3.2-fold (0.50 log units) below; low and high end bracket the measured number.
By their numbers in this assay, from the lowest: compounds 2 and 1 (each within the scatter of the next); then compound 3.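

Exchanging 4-acetylpiperazin-1-yl for dimethylamino on this aromatic carbon gives a 4.9-fold higher number from compound 2 to compound 3 (0.69 log units; beyond the scatter) and so shows that this position is sensitive to the group it carries. Here, the smaller group without a ring goes with weaker inhibition. Nothing measured on these compounds explains this shift.

The compounds shown leave open whether the ring itself or the acetyl group on it matters. A piperazin-1-yl group with a free amine or a morpholin-4-yl group on this carbon would help to separate the two.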